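This account rests on a few compounds, and the source may have more. Where it says the series, first, only, none or still open, it means among the compounds named here.

Measured in an ADME assay on Vero cells (Chlorocebus sabaeus) for cytotoxicity; a higher number here means that more compound is tolerated, a lower number that less compound is tolerated:
- compound 1 `O=[N+]([O-])c1ccc(-c2nc3ccccc3[nH]2)c([N+](=O)[O-])c1`: > 100000 nM
- compound 2 `COc1cc(OC)cc(-c2nc3cc(C(F)(F)F)ccc3[nH]2)c1`: > 100000 nM

In this assay compound 2 stands at > 100000 nM, which is a limit and not a number. Compound 1 gives > 100000 nM, which is also a limit. Within the data shown here, the series so far therefore offers only (the limit of > 100000 nM in this assay, at which 2 of the 2 values shown sit), and no measured step between compounds is available.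

Compound 3 `COc1cc(-c2nc3cc(C(F)(F)F)ccc3[nH]2)cc(OC)c1OC` follows from compound 2 by methoxy in place of hydrogen on an aromatic carbon, ortho to two methoxy groups and para to a large group (methoxy in place of hydrogen on an aromatic carbon). No shift beyond the scatter, in either direction, is expected in this assay. The expected size is a number no higher from compound 2 to compound 3 (the limit leaves the size open), and another limit is the likeliest report. The estimate for compound 3 is 100000 nM, with an expected range from 30000 nM to 200000 nM.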

Compound 3, half-maximal cytotoxic concentration: 29000 nM
Compound 3: the middle estimate sits 3.4-fold (0.54 log units) above what was measured; the whole stated range lies above it.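

In this assay, methoxy in place of hydrogen on an aromatic carbon, ortho to two methoxy groups and para to a large group, gives an at least 3.4-fold lower number from compound 2 to compound 3 (0.53 log units; beyond the scatter). This position is therefore not silent in this assay, since a single added methoxy is enough to bring a number into a series that otherwise shows only a limit: the limit of > 100000 nM in this assay, at which 2 of the 3 values shown sit. Compound 2 gives only a limit, so the step has a lower bound on its size and no upper one.

The compounds shown leave open whether another group at this position, such as a hydroxy, a chlorine or an amine, lowers the number as well, and whether a longer chain in place of the methoxy lowers it further. As far as these compounds go, with one step, it also remains open whether the same change gives a similar result on the core of compound 1.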